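Methoxy for Chloro, Carried onto a Second Core

A few compounds are considered here, and "the series" means these few. Any claim that something is new, unique, unknown or untested is made for them only; others in the source may bear on it.

Compound 1 `O=C(CN1CCN(C(=O)c2cccc(Cl)c2)CC1)N1CCN(CCCc2c[nH]c3ccc(F)cc23)CC1` is the reference. In an ADME assay on HEK293 cells (Homo sapiens) for cytotoxicity, read by MTT assay, with a stated time of 72 h (a higher number here means a weaker inhibitor, a lower number a stronger inhibitor), compound 1 gives 66200 nM. Compound 2 `COc1cccc(C(=O)N2CCN(CC(=O)N3CCN(CCCc4c[nH]c5ccc(F)cc45)CC3)CC2)c1` carries the change methoxy in place of chloro on an aromatic carbon and in this assay compound 2 gives 87100 nM, a step of a 1.3-fold higher number from compound 1 to compound 2 (0.12 log units; within the scatter). Compound 3 `COc1ccc2[nH]cc(CCCN3CCN(C(=O)CN4CCN(C(=O)c5cccc(Cl)c5)CC4)CC3)c2c1` differs from compound 1 in its core by methoxy in place of fluoro on an aromatic carbon; in this assay compound 3 gives 143000 nM, a step of a 2.2-fold higher number from compound 1 to compound 3 (0.33 log units; beyond the scatter). Compound 4 `COc1cccc(C(=O)N2CCN(CC(=O)N3CCN(CCCc4c[nH]c5ccc(OC)cc45)CC3)CC2)c1` is not yet measured. It arises from compound 3 by methoxy in place of chloro on an aromatic carbon, the same change that turned compound 1 into compound 2, with nothing differing around the place. Because the earlier step was a 1.3-fold higher number from compound 1 to compound 2 (0.12 log units; within the scatter), a step of a 1.3-fold higher number from compound 3 to compound 4 (0.10 log units; within the scatter) is expected here as well. Compound 4 is therefore estimated at 180000 nM, with a likely range from 90000 nM to 360000 nM.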

Compound 4, half-maximal inhibitory concentration: > 200000 nM
Compound 4: only a limit was reported (the forecaster's own chance of this, stated with the estimate: 20%); at least 1.1-fold (0.04 log units) between middle value and limit.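

In this assay compound 4 gives > 200000 nM, which is a limit of the assay and not a number. Carried onto the core of compound 3, methoxy in place of chloro gives an at least 1.3-fold higher number from compound 3 to compound 4 (0.14 log units; that floor lies within the scatter), so the direction matches the earlier step, but the size on this core is not fixed: the same change on two cores in this assay, a 1.3-fold higher number (0.12 log units; within the scatter) from compound 1 to compound 2 and an at least 1.3-fold higher number (0.14 log units; that floor lies within the scatter) from compound 3 to compound 4; the limit leaves it open whether they differ Methoxy in place of fluoro, read on the second pair, gives an at least 2.2-fold higher number from compound 2 to compound 4 (0.36 log units; beyond the scatter), and this too is only a floor: the same change on two cores in this assay, a 2.2-fold higher number (0.33 log units; beyond the scatter) from compound 1 to compound 3 and an at least 2.2-fold higher number (0.36 log units; beyond the scatter) from compound 2 to compound 4; the limit leaves it open whether they differ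

The compounds shown leave open whether an amine or a carboxylic acid in place of chloro would follow the same course on both cores. How far compound 4 lies past its limit also stays open: the limit of > 200000 nM in this assay, at which 1 of the 4 values shown sits.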